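This account rests on a few compounds, and the source may have more. Where it says the series, first, only, none or still open, it means among the compounds named here.

In an assay on THP-1 cells for inhibition of nuclear factor NF-kappa-B complex (Homo sapiens), with stated times of 2 h and 16 h (on this read-out lower numbers stand for stronger inhibition and higher numbers for weaker inhibition), compound 1 `CC(C)CCCOc1cccc(O)c1C(=O)/C=C/c1ccc(O)cc1` gives 11000 nM. Compound 2 `O=C(/C=C/c1ccc(O)cc1)c1c(O)cccc1OCCC1CCCCC1` differs from it in the chain carried by the ether oxygen of the shared core. For compound 2 the read-out is a limit of the assay, > 30000 nM, not a number. The step of an at least 2.7-fold higher number from compound 1 to compound 2 (0.43 log units; beyond the scatter) is therefore known only as a lower bound, set by the limit of > 30000 nM in this assay, at which 1 of the 2 values shown sits. Compound 2 thus stands at the weak end of the two values shown, and its true number may lie anywhere past that limit.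

Compound 3 `CCC(CC)COc1cccc(O)c1C(=O)/C=C/c1ccc(O)cc1` is next. Against compound 2 the change is pentan-3-yl in place of cyclohexylmethyl on a saturated chain carbon bound to an oxygen on an aromatic ring. Within the data shown here, only one measured step bears on it, an at least 2.7-fold higher number from compound 1 to compound 2 (0.43 log units; beyond the scatter), which brought in the six-membered non-aromatic ring and cost potency. Compound 3 removes that ring again and carries a branched acyclic chain, as compound 1 does, though a different one, so part of the loss is expected to be recovered. The step of an at least 2.1-fold lower number from compound 2 to compound 3 (0.33 log units; beyond the scatter) is expected to run toward lower numbers. Its size is uncertain, as the number for compound 2 is known only as a limit. For compound 3 the estimate is 14000 nM, with a range from 5000 nM to 40000 nM, and a fair chance that this assay again returns only its limit.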

Compound 3, half-maximal inhibitory concentration: 12000 nM
Beside the measured number, compound 3's estimate is 1.2-fold (0.07 log units) above it; the range from low to high includes it.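

Replacing cyclohexylmethyl with pentan-3-yl on the saturated chain carbon bound to an oxygen on an aromatic ring gives an at least 2.5-fold lower number from compound 2 to compound 3 (0.39 log units; beyond the scatter) in this assay, so the weak reading of compound 2 goes with its ring-bearing chain and not with substitution on this ether oxygen as such. Compound 2 is held at a limit, not a number, which makes the size of that step only a lower bound: the limit of > 30000 nM in this assay, at which 1 of the 3 values shown sits. Between the two acyclic branched chains, the change from isopentyl to pentan-3-yl gives a 1.1-fold higher number from compound 1 to compound 3 (0.04 log units; within the scatter), so this assay does not separate these two chains, and their different shapes leave the read-out in place.

Going by these compounds, whether the loss seen with compound 2 follows from the six-membered ring itself or from the overall size of the chain stays open, and a cyclopentylmethyl group or a straight hexyl chain on the same oxygen would bear on that question. Also open, on these data alone, is whether a chain ending in an amine or a carboxylic acid would move the read-out away from that of compound 1, 11000 nM.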